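The source may hold more compounds than are shown below. What is called first, only, known or untested is meant among the compounds shown, and "the series" means these compounds.

Among the measured compounds shown here, in a functional assay on MCF7 cells (Homo sapiens) for cytotoxicity, read by MTT assay, with a stated time of 72 h (on this read-out lower numbers stand for stronger inhibition and higher numbers for weaker inhibition), compound 2 (`COc1ncc(-c2ccc3nc(NC(=O)NCCN4CCCCC4)nn3c2)cc1NS(=O)(=O)c1ccc(F)cc1`) stands lowest of the two numbers so far at 200 nM and compound 1 (`COc1ncc(-c2ccc3nc(NC(=O)NCC(=O)N4CCCCC4)nn3c2)cc1NS(=O)(=O)c1ccc(F)cc1`) stands at 570 nM on the same read-out. Compound 3 (`COc1ncc(-c2ccc3nc(NC(=O)NCC(=O)N4CCOCC4)nn3c2)cc1NS(=O)(=O)c1ccc(F)cc1`) has (morpholin-4-yl)carbonyl in place of (piperidin-1-yl)methyl on a saturated chain carbon bound to an amide-type nitrogen. For the measured compounds named here, the one measured step bearing on this change is a 2.9-fold lower number from compound 1 to compound 2 (0.45 log units; beyond the scatter) with (piperidin-1-yl)methyl replacing (piperidin-1-yl)carbonyl, and compound 3 returns to a carbonyl, so a step of similar size is expected in the opposite direction, toward a higher number in this assay for this series. Going by the values given here, no measured step covers the six-membered ring with 2 hetero atoms, which leaves the range wide. The expected change is a 3.3-fold higher number from compound 2 to compound 3 (0.51 log units; beyond the scatter) and remains an estimate. Compound 3 is estimated at 650 nM with an expected range from 280 nM to 1500 nM for now.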

Compound 3, half-maximal inhibitory concentration: 630 nM
Compound 3: middle estimate off by 1.0-fold (0.01 log units), on the high side; measured number inside the range.
By their numbers in this assay, from the lowest: compound 2; then compounds 1 and 3 (each within the scatter of the next).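

In this assay, morpholin-4-yl in place of piperidin-1-yl on a carbonyl carbon gives a 1.1-fold higher number from compound 1 to compound 3 (0.04 log units; within the scatter), so with the carbonyl present, this ring exchange has no readable effect. The combined change gives a 3.2-fold higher number from compound 2 to compound 3 (0.50 log units; beyond the scatter), close in size to the opposite step, a 2.9-fold lower number from compound 1 to compound 2 (0.45 log units; beyond the scatter). Among these three compounds, the separation therefore follows carbonyl versus methyl rather than the identity of the ring, with compound 2 the only member carrying the methyl. No measurement is available to explain this difference.

Going by these compounds, it remains open whether the ring exchange is equally silent in a (morpholin-4-yl)methyl group, which would test the reading without the carbonyl. The behaviour of an open-chain amine such as dimethylamino, or of a longer chain ending in piperidin-1-yl, is also unresolved.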